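A few compounds are considered here, and "the series" means these few. Any claim that something is new, unique, unknown or untested is made for them only; others in the source may bear on it.

In a functional assay on A20 cells (Mus musculus) for inhibition, with stated times of 1 h, 16 h and 24 h (a lower number here means a stronger inhibitor, a higher number a weaker inhibitor), compound 1 (`N#CCNC(=O)[C@@H]1C[C@@H](S(=O)(=O)CC2CC2)C[C@H]1C(=O)N1CCOCC1`) reads 4510 nM and compound 2 (`CC(C)(C#N)NC(=O)[C@@H]1C[C@@H](S(=O)(=O)c2ccccc2)C[C@H]1C(=O)N1CCOCC1`) reads 43 nM while compound 3 (`C[C@@H]1CN(C(=O)[C@@H]2C[C@H](S(=O)(=O)c3ccccc3)C[C@H]2C(=O)NC2(C#N)CC2)C[C@H](C)O1`) gives the lowest number of the three at 1 nM with both gaps beyond the scatter. The next compound is compound 4 (`N#CC1(NC(=O)[C@@H]2C[C@@H](S(=O)(=O)c3ccccc3)C[C@H]2C(=O)N2CC3(COC3)C2)CC1`). Its change from compound 3 is a group of 7 heavy atoms (5 carbon, 1 nitrogen, 1 oxygen; 2 four-membered non-aromatic rings with 1 hetero atom each) in place of a group of 8 heavy atoms (6 carbon, 1 nitrogen, 1 oxygen; one six-membered non-aromatic ring with 2 hetero atoms), on a carbonyl carbon and both groups have no hydrogen-bond donors and no net charge. Among the compounds with values here, no measured pair isolates this change, so any expectation here is a judgement. A modest rise in the number is expected because compound 3 at 1 nM is already the lowest reading in the series. The expected size is a 4.0-fold higher number from compound 3 to compound 4 (0.60 log units; beyond the scatter) towards a weaker inhibitor. Compound 4 is estimated at 4 nM (1 nM to 15 nM).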

Compound 4, half-maximal inhibitory concentration: 248 nM
The estimate for compound 4 lay 62-fold (1.79 log units) below the measured number; the whole stated range lies below it.
By their numbers in this assay, from the lowest: compound 3; then compound 2; then compound 4; then compound 1.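

Exchanging 2,6-dimethylmorpholin-4-yl for the group with 2 four-membered non-aromatic rings, on a carbonyl carbon, gives a 250-fold higher number from compound 3 to compound 4 (2.39 log units; beyond the scatter) in this assay. Within the data shown here, this is the first step confined to one place, and it shows that the readout is highly sensitive to the group at this position. No available measurement bears on the reason for this shift.

Going by these compounds, it remains open whether the two methyl groups or the six-membered ring accounts for the difference. Unsubstituted morpholin-4-yl or piperidin-1-yl on the core of compound 3 would help separate these.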